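This account rests on a few compounds, and the source may have more. Where it says the series, first, only, none or still open, it means among the compounds named here.

In a functional assay on A549 cells (Homo sapiens) for antiproliferative activity, read by MTT assay, with a stated time of 72 h (on this read-out higher numbers stand for weaker inhibition and lower numbers for stronger inhibition), compound 1 (`NC1=NC2(CCSCC2)N(OCCCOc2ccc(Cl)c(Cl)c2)C(N)=N1`) gives 1 nM and compound 3 (`NC1=NC2(CCSCC2)N(OCCCOc2cccc(Cl)c2Cl)C(N)=N1`) gives 1 nM, so these two stand level at the lowest number of the three measured. Compound 2 (`NC1=NC2(CCOCC2)N(OCCCOc2ccccc2)C(N)=N1`) gives 1080 nM, a far higher number. Compound 4 (`NC1=NC2(CCSCC2)N(OCCCOc2ccccc2Br)C(N)=N1`) keeps the rest of compound 3 and changes one group: 2-bromophenyl in place of 2,3-dichlorophenyl on an oxygen on a saturated carbon. In words, this is 2-bromophenyl in place of 2,3-dichlorophenyl on an oxygen on a saturated carbon.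

For the measured compounds named here, one measured step bears on this change, the exchange of 3,4-dichlorophenyl for 2,3-dichlorophenyl, which gave no change at the digits printed from compound 1 to compound 3 (within the scatter). Going by the values given here, that step is only a loose guide, as no measured compound carries a bromine. Since compound 3 already sits at 1 nM, a modest move toward weaker inhibition is more likely than a further fall. The expected step in this assay is therefore small: a 3.0-fold higher number from compound 3 to compound 4 (0.48 log units; beyond the scatter). For compound 4 the estimated value is 3 nM, with an expected range of 1 nM to 20 nM.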

Compound 4, half-maximal inhibitory concentration: 40 nM
The estimate for compound 4 lay 13-fold (1.12 log units) below the measured number; measured number above the stated range.
By their numbers in this assay, from the lowest: compounds 1 and 3 (each within the scatter of the next); then compound 4; then compound 2.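

In this assay, the group on this oxygen does not tolerate every halogen-bearing phenyl: moving between the two dichlorophenyl groups left the number unchanged, yet 2-bromophenyl gives a 40-fold higher number from compound 3 to compound 4 (1.60 log units; beyond the scatter) and also a 40-fold higher number from compound 1 to compound 4 (1.60 log units; beyond the scatter). The change removes two chlorine atoms and brings in one bromine, so the number of halogen atoms and their kind change together, and this step cannot separate the two. Nothing available here explains the rise.

As far as these compounds go, it remains open whether 2-chlorophenyl, which carries a single chlorine, would stand with compound 3 or with compound 4. From the compounds shown here alone, it is also open how 2-methoxyphenyl, which has no halogen at all, would behave on the core of compound 3.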